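A few compounds are considered here, and "the series" means these few. Any claim that something is new, unique, unknown or untested is made for them only; others in the source may bear on it.

Measured compounds:
compound 1 `NS(=O)(=O)c1ccc(Nc2nc(N/N=C/c3ccc(C(F)(F)F)cc3)nc(Nc3ccccc3)n2)cc1`: 2380 nM
compound 2 `Cc1nn(-c2ccccc2)cc1/C=N/Nc1nc(Nc2ccccc2)nc(Nc2ccc(S(N)(=O)=O)cc2)n1`: 2840 nM

Among the measured compounds shown here, in a functional assay on KM12 cells (Homo sapiens) for inhibition, read by sulforhodamine B assay, with a stated time of 48 h (a higher number here means a weaker inhibitor of growth, a lower number a stronger inhibitor of growth), compound 2 gives 2840 nM, the higher of the two numbers so far; the nearest is compound 1, which in this assay gives 2380 nM, and the gap between the two lies within the scatter. Compound 3 `NS(=O)(=O)c1ccc(Nc2nc(N/N=C/c3ccccn3)nc(Nc3ccccc3)n2)cc1` is not yet measured in this assay. The change from compound 2 to compound 3 is pyridin-2-yl in place of 3-methyl-1-phenyl-1H-pyrazol-4-yl on a carbon with a double bond to nitrogen.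

For the measured compounds named here, only one measured step bears on this position, the exchange of the group on the same carbon with a double bond to nitrogen, a 1.2-fold higher number from compound 1 to compound 2 (0.08 log units; within the scatter). That exchange between two different groups left the number essentially where it was, and nothing else in the series tells how this position responds. For a further exchange at the same place no step beyond the scatter is therefore expected in this assay, in either direction. Compound 3 is expected to give 2600 nM, with a range of 1000 nM to 7000 nM. The expected step is a 1.1-fold lower number from compound 2 to compound 3 (0.04 log units; within the scatter), that is, no change beyond the scatter.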

Compound 3, concentration for 50% growth inhibition: 2140 nM
Estimate against measurement, compound 3: 1.2-fold (0.08 log units) above; the measured number falls inside the stated range.
By their numbers in this assay, from the lowest: compounds 3, 1 and 2 (each within the scatter of the next).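

In this assay, the place on the carbon with a double bond to nitrogen now carries three different groups, and the exchange for pyridin-2-yl gives a 1.3-fold lower number from compound 2 to compound 3 (0.12 log units; within the scatter) and a 1.1-fold lower number from compound 1 to compound 3 (0.05 log units; within the scatter). Among the compounds shown here, the earlier pair showed only one exchange; these steps add a group with a ring nitrogen, and pyridin-2-yl, with 6 heavy atoms and one ring, stays within the scatter of 3-methyl-1-phenyl-1H-pyrazol-4-yl, with 12 heavy atoms and two rings, so across these three compounds neither the size of the group nor a nitrogen in its ring separates the numbers. No measurement shown here accounts for this flat response, and it cannot be said what sets the shared level of growth inhibition.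

Going by these compounds, all three groups on this carbon are aromatic rings, so the response to a primary amine, a carboxylic acid or a saturated alkyl chain at the same place remains open. The rest of the structure is identical in compounds 1, 2 and 3, which leaves open how the number would respond to an exchange anywhere else on the shared core.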